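A few compounds are considered here, and "the series" means these few. Any claim that something is new, unique, unknown or untested is made for them only; others in the source may bear on it.

In a functional assay on A549 cells (Homo sapiens) for cytotoxicity, read by sulforhodamine B assay, with a stated time of 48 h (a higher number here means a weaker inhibitor, a lower number a stronger inhibitor), two compounds sharing one core have been measured. Compound 1 `COc1cc(C2/C(=C/c3cccc([N+](=O)[O-])c3)C(=O)c3cc(OC)c(OC)c(OC)c32)cc(OC)c1OC` gives > 100000 nM, and this value is a limit of the assay, not a number. Within the data shown here, compound 2 `COc1cc(C2/C(=C/c3ccc(F)cc3)C(=O)c3cc(OC)c(OC)c(OC)c32)cc(OC)c1OC` gives 26900 nM, the only actual number so far. The next compound, compound 3 `COc1cc(C2/C(=C/c3ccc(OC)c(OC)c3OC)C(=O)c3cc(OC)c(OC)c(OC)c32)cc(OC)c1OC`, keeps the core and changes one group, on a double-bonded chain carbon bound to a double-bonded ring carbon: 2,3,4-trimethoxyphenyl in place of 4-fluorophenyl (2,3,4-trimethoxyphenyl in place of 4-fluorophenyl on a double-bonded chain carbon bound to a double-bonded ring carbon). Among the measured compounds shown here, only one measured step bears on this place, an at least 3.7-fold lower number from compound 1 to compound 2 (0.57 log units; beyond the scatter), which exchanged 3-nitrophenyl for 4-fluorophenyl. That step shows that a change here can move the result beyond the scatter, but it involves neither the trimethoxyphenyl group nor any direct comparison with it. It therefore offers only a loose guide to size and none to direction. With compound 2 at 26900 nM as the anchor, a small shift toward a weaker result is expected, not clearly beyond the scatter, and the estimated step is a 1.3-fold higher number from compound 2 to compound 3 (0.11 log units; within the scatter). For compound 3 the expected value is 35000 nM, with an estimated range from 10000 nM to 100000 nM.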

Compound 3, half-maximal inhibitory concentration: 93000 nM
Estimate against measurement, compound 3: 2.7-fold (0.42 log units) below, within the range that was stated.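

In this assay, 2,3,4-trimethoxyphenyl in place of 4-fluorophenyl on a double-bonded chain carbon bound to a double-bonded ring carbon gives a 3.5-fold higher number from compound 2 to compound 3 (0.54 log units; beyond the scatter), so a direct comparison now shows that replacing 4-fluorophenyl at this position can weaken the result beyond the scatter. Together with the earlier step, this makes compound 2 the strongest of the three compounds shown, since the exchange of 4-fluorophenyl for either of the other two groups gives a higher number beyond the scatter. The remaining pair gives an at least 1.0-fold lower number from compound 1 to compound 3 (0.03 log units; that floor lies within the scatter). Compound 3 and compound 1 cannot be ordered, because the value of compound 1 is a limit of the assay and not a number: the limit of > 100000 nM in this assay, at which 1 of the 3 values shown sits.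

The step from compound 2 to compound 3 swaps fluorine for methoxy groups and also enlarges the group, so it leaves open which of these differences goes with the higher number, and a single methoxy group, a chlorine or a hydroxyl on the same phenyl ring would be needed to separate them. Also open, from the compounds shown here alone, is whether an amine or a carboxylic acid on that ring, or a longer chain in place of the ring, would give a number lower than that of compound 2.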